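This account rests on a few compounds, and the source may have more. Where it says the series, first, only, none or still open, it means among the compounds named here.

Working notes on the series. In an ADME assay on MONO-MAC-6 cells (Homo sapiens) for cytotoxicity, read by MTT assay, with a stated time of 16 h (on this read-out lower numbers stand for stronger inhibition and higher numbers for weaker inhibition), compound 1 `O=C(Nc1ccc(C(F)(F)F)cc1)c1cc(Cl)ccc1O` gives 5300 nM, compound 2 `O=C(Nc1ccc(C(F)(F)F)cc1)c1cc(Br)ccc1O` gives 7600 nM, and compound 3 `O=C(Nc1ccc(Cl)c(Cl)c1)c1cc(Br)ccc1O` gives 3500 nM. Compound 1 holds the middle place among these three numbers, and both of the others lie within the scatter of it.

Compound 4 `O=C(c1ccccc1)c1ccc(NC(=O)c2cc(Cl)ccc2O)cc1` is the next to be read against compound 1: benzoyl in place of trifluoromethyl on an aromatic carbon. In words, benzoyl stands in place of trifluoromethyl on an aromatic carbon, para to a large group.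

For the measured compounds named here, the one measured single-site step is a 1.4-fold higher number from compound 1 to compound 2 (0.16 log units; within the scatter), which lies within the scatter but concerns the halogen, not this site. Going by the values given here, no measured step covers a benzoyl group. Among the compounds with values here, compound 3, which carries no trifluoromethyl, still gives 3500 nM, so the numbers so far stay in a narrow band. In this assay no step beyond the scatter is therefore expected, and no direction can be argued with confidence.

The expected step is a 1.1-fold higher number from compound 1 to compound 4 (0.05 log units; within the scatter). For compound 4 the estimated value is 6000 nM, with an expected range from 2000 nM to 18000 nM.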

Compound 4, half-maximal inhibitory concentration: 48000 nM
Estimate against measurement, compound 4: 8.0-fold (0.90 log units) below; the whole stated range lies below it.
By their numbers in this assay, from the lowest: compounds 3, 1 and 2 (each within the scatter of the next, the first and the last beyond it); then compound 4.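

In this assay this site gives the only step beyond the scatter among the compounds shown: benzoyl in place of trifluoromethyl, para to a large group, brings a 9.1-fold higher number from compound 1 to compound 4 (0.96 log units; beyond the scatter), whereas the halogen change gave only a 1.4-fold higher number from compound 1 to compound 2 (0.16 log units; within the scatter). The number thus depends on what stands at this position, and the change moves it toward weaker inhibition, although this one step cannot separate the effect of the added aromatic ring from that of the added carbonyl. No measurement shown accounts for the size of the step, and its cause remains unassigned.

Still open, on these data alone, is how an amine, a carboxylic acid or a simple phenyl group at this position would read against compound 1. Also open, as far as these compounds go, is whether benzoyl would give a similar step with bromo in place of chloro.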